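The source may hold more compounds than are shown below. What is called first, only, known or untested is meant among the compounds shown, and "the series" means these compounds.

Measured so far:
compound 1 `CN(c1cnccc1SCCCCCC(=O)O)c1ccc(C#N)c2ccccc12` gives 3760 nM in an assay on HEK293 cells for inhibition of solute carrier family 22 member 12 (Homo sapiens), read by scintillation counting, with stated times of 30 min and 15 min; on this read-out higher numbers stand for weaker inhibition and lower numbers for stronger inhibition;
compound 2 `CN(c1cnccc1SCCCC(=O)O)c1ccc(C#N)c2ccccc12` gives 2580 nM in this assay.

On these two numbers compound 2 sits within the usual scatter of compound 1, so neither can be called stronger. Compound 3 `CN(c1cnccc1SC(C)(C)C(=O)O)c1ccc(C#N)c2ccccc12` has 1-carboxy-1-methylethyl in place of 3-carboxypropyl on a sulfur. Among the compounds with values here, the only measured step that bears on the chain, a 1.5-fold lower number from compound 1 to compound 2 (0.16 log units; within the scatter), shortened it and stayed within the scatter; no measured step shows a branched chain. Compound 3 is therefore expected to stay close to compound 2, with a 1.2-fold higher number from compound 2 to compound 3 (0.09 log units; within the scatter). For compound 3 the estimated value is 3200 nM, within a range of 1100 nM to 9500 nM.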

Compound 3, half-maximal inhibitory concentration: 5360 nM
Estimate against measurement, compound 3: 1.7-fold (0.22 log units) below; low and high end bracket the measured number.
By their numbers in this assay, from the lowest: compounds 2, 1 and 3 (each within the scatter of the next, the first and the last beyond it).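

In this assay, within the data shown here, the rearrangement of the same atoms from 3-carboxypropyl to the branched 1-carboxy-1-methylethyl on the sulfur gives a 2.1-fold higher number from compound 2 to compound 3 (0.32 log units; beyond the scatter) and is the first step here to pass the scatter, if only modestly. Set against the longer 5-carboxypentyl, the same group gives a 1.4-fold higher number from compound 1 to compound 3 (0.15 log units; within the scatter) and stays within it, so the branched chain separates only from 3-carboxypropyl. Nothing available explains this shift. The compounds shown leave open how this position would respond to an amide or a tetrazole in place of the carboxylic acid.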